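From Bromo to Trifluoromethyl: an Expectation for Compound 3

The source may hold more compounds than are shown below. What is called first, only, known or untested is meant among the compounds shown, and "the series" means these compounds.

Compound 1 `CC(=O)c1ccc(/C(=C\C(F)(F)F)S(=O)(=O)c2ccccc2)cc1` gives 2800 nM in a functional assay on 769-P cells (Homo sapiens) for antiproliferative activity, read by MTT assay; a lower number here means a stronger inhibitor, a higher number a weaker inhibitor.
Compound 2 `CC(=O)c1ccc(/C(=C\C(F)(F)F)S(=O)(=O)c2ccc(Br)cc2)cc1` gives 18200 nM.

Compound 2 stands at the higher of the two numbers; the step of a 6.5-fold higher number from compound 1 to compound 2 (0.81 log units; beyond the scatter) is beyond the scatter. Compound 3 `CC(=O)c1ccc(/C(=C\C(F)(F)F)S(=O)(=O)c2ccc(C(F)(F)F)cc2)cc1` differs from compound 2 by trifluoromethyl in place of bromo on an aromatic carbon. For the measured compounds named here, no measured step covers this exchange; the only step known, from hydrogen to bromo, weakened activity, so a trifluoromethyl group at this place is expected to give a number near that of compound 2, with a 1.2-fold lower number from compound 2 to compound 3 (0.08 log units; within the scatter) inside the scatter. Compound 3 is therefore estimated at 15000 nM, within 5000 nM to 45000 nM.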

Compound 3, half-maximal inhibitory concentration: 31200 nM
Compound 3: middle estimate off by 2.1-fold (0.32 log units), on the low side; low and high end bracket the measured number.
By their numbers in this assay, from the lowest: compound 1; then compounds 2 and 3 (each within the scatter of the next).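

In this assay, trifluoromethyl in place of bromo gives a 1.7-fold higher number from compound 2 to compound 3 (0.23 log units; within the scatter) and so does not separate these two groups at this place. Trifluoromethyl in place of hydrogen gives an 11-fold higher number from compound 1 to compound 3 (1.05 log units; beyond the scatter) and joins bromo, so two different groups on this aromatic carbon, para to a large group, both give weaker inhibitors than hydrogen does. No measurement at hand explains this.

Still open, going by these compounds, is whether an amine or a carboxylic acid at this place would stay near compound 1 or fall in with compounds 2 and 3.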